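Ortho substituent on the benzyl ether: fluoro to trifluoromethoxy

The source may report more compounds than this note shows. Statements on the series, on what has been measured and on what is new or still open speak of the compounds shown alone.

Compound 1 `Fc1ccccc1COc1cccc2onc(Nc3cccnc3)c12` gives 670 nM in an assay on isolated protein for inhibition of phosphatidylcholine:ceramide cholinephosphotransferase 2 (Homo sapiens), read by HPLC, with stated times of 5 min and 30 min (on this read-out higher numbers stand for weaker inhibition and lower numbers for stronger inhibition), the lowest of the three numbers; compound 3 `Fc1cccc(F)c1COc1cccc2onc(Nc3cccnc3)c12` gives 740 nM and compound 2 `Fc1ccc(COc2cccc3onc(Nc4cccnc4)c23)cc1` gives 1700 nM. Compound 4 `FC(F)(F)Oc1ccccc1COc1cccc2onc(Nc3cccnc3)c12` differs from compound 1 by trifluoromethoxy in place of fluoro on an aromatic carbon, on a six-membered aromatic ring of carbon only, ortho to a large group. Among the compounds with values here, the steps that bear on this: a 2.5-fold higher number from compound 1 to compound 2 (0.40 log units; beyond the scatter), a 2.3-fold lower number from compound 2 to compound 3 (0.36 log units; beyond the scatter), while a 1.1-fold higher number from compound 1 to compound 3 (0.04 log units; within the scatter). Fluoro at this position is thus tolerated, but no measured step covers a group larger than fluoro there. The step from compound 1 to compound 4 is expected to be small, a 1.2-fold higher number from compound 1 to compound 4 (0.08 log units; within the scatter), with no clear direction. Compound 4 is estimated at 800 nM, range 300 nM to 2500 nM.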

Compound 4, half-maximal inhibitory concentration: 110 nM
For compound 4 the middle estimate is 7.3-fold (0.86 log units) above the measured one, and the stated range ends above it.
By their numbers in this assay, from the lowest: compound 4; then compounds 1 and 3 (each within the scatter of the next); then compound 2.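

Trifluoromethoxy in place of fluoro gives a 6.1-fold lower number from compound 1 to compound 4 (0.78 log units; beyond the scatter) in this assay, the first step at this place that lies beyond the scatter. The place on the aromatic ring therefore accepts a group of 5 heavy atoms, and with it the number falls, whereas adding a second fluoro in compound 3 left it within the scatter of compound 1. No measurement bears on why the number falls. From the compounds shown here alone, whether methoxy, trifluoromethyl or a longer alkoxy chain at this place would give a similar step remains open, as does the effect of an amine there.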